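This account rests on a few compounds, and the source may have more. Where it says the series, first, only, none or still open, it means among the compounds named here.

Measured so far in a functional assay on NALM-6 cells (Homo sapiens) for cytotoxicity, with a stated time of 72 h; on this read-out lower numbers stand for an effect already at smaller amounts and higher numbers for an effect only at larger amounts of compound:
- compound 1 `C=C[C@@](C)(/C=C/c1ccc(O)cc1)CC/C=C(C)/C=N/N` gives > 43400 nM as a limit
- compound 2 `C=C[C@@](C)(/C=C/c1ccc(O)cc1)CC/C=C(\C)CO` gives > 43400 nM as a limit

Compound 2 reads > 43400 nM, which is a limit of the assay and not a number. The whole set so far comes down to the limit of > 43400 nM in this assay, at which 2 of the 2 values shown sit, so compound 2 has no measured neighbour with a true number. Within the data shown here, the one measured step is a step that the two limits leave unreadable from compound 1 to compound 2 and gives no size to carry forward.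

Compound 3 `C=C[C@@](C)(/C=C/c1ccc(O)cc1)CC/C=C(C)/C=C/C(=O)OCC` is still to be measured. Its difference from compound 2 is 2-(ethoxycarbonyl)ethenyl in place of hydroxymethyl on a double-bonded chain carbon bound to a double-bonded chain carbon and a saturated chain carbon. Among the measured compounds shown here, no measured step covers this exchange, so the only anchor is the reading of compound 2 , which stays the limit > 43400 nM here. A readable change in this assay could only run toward lower numbers, and a modest one is expected, with a second limit quite possible. The expected step is an at least 1.4-fold lower number from compound 2 to compound 3 (0.16 log units; that floor lies within the scatter) and is poorly constrained. The estimate for compound 3 is 30000 nM, with an expected range from 10000 nM to 60000 nM as its ends.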

Compound 3, half-maximal effective concentration: 815 nM
For compound 3 the middle estimate is 37-fold (1.57 log units) above the measured one, and the stated range ends above it.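

In this assay, among these compounds, the position on a double-bonded chain carbon bound to a double-bonded chain carbon and a saturated chain carbon now proves able to move the read-out: 2-(ethoxycarbonyl)ethenyl in place of hydroxymethyl gives an at least 53-fold lower number from compound 2 to compound 3 (1.72 log units; beyond the scatter), and compound 3 supplies the first true number. The same group, set against the group of compound 1, gives an at least 53-fold lower number from compound 1 to compound 3 (1.72 log units; beyond the scatter), so this large shift appears against both earlier groups at this place. The step between compound 1 and compound 2 cannot be read, and the sizes of both new steps are floors, since each starts from a limit of the assay and not a number: the limit of > 43400 nM in this assay, at which 2 of the 3 values shown sit.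

The compounds shown leave open which part of 2-(ethoxycarbonyl)ethenyl goes with the lower number: the ethyl ester, the chain double bond or the length of the group. A carboxylic acid or a primary amide in place of the ethyl ester, or a saturated two-carbon chain in place of the ethenyl part, would separate these parts at the same position.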